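Swapping Methyl for Iodine on a Thiosugar Nucleoside

A few compounds are considered here, and "the series" means these few. Any claim that something is new, unique, unknown or untested is made for them only; others in the source may bear on it.

Compound 1 `Cc1cn([C@@H]2S[C@H](CO)[C@@H](O)[C@@H]2O)c(=O)[nH]c1=O` was tested in a functional assay on CCRF-HSB-2 cells (Homo sapiens) for antiproliferative activity; a higher number here means a weaker inhibitor, a lower number a stronger inhibitor. In this assay compound 1 gave only a limit of the measurement, > 100 ug/mL, not a number. Compound 2 `Nc1ncnc2c1ncn2[C@H]1S[C@H](CO)[C@@H](O)[C@@H]1O` is a related nucleoside. In this assay compound 2 also gave only a limit, > 100 ug/mL. Both compounds thus stand at the limit of > 100 ug/mL in this assay, at which 2 of the 2 values shown sit. Compound 3 `O=c1[nH]c(=O)n([C@@H]2S[C@H](CO)[C@@H](O)[C@@H]2O)cc1I` carries one change from compound 1: iodo in place of methyl on an aromatic carbon. Among the compounds with values here, with no measured step available to guide the expectation, the change is expected to move the result little, if at all beyond the scatter. Compound 3 is estimated at 100 ug/mL, with a range from 30 ug/mL to 300 ug/mL, which corresponds to an expected step of a number no higher from compound 1 to compound 3 (the limit leaves the size open).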

Compound 3, half-maximal inhibitory concentration: > 100 ug/mL
Compound 3 was reported as a limit (the forecaster's own chance of this, stated with the estimate: 60%); the middle value lies on the limit itself.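

No step from compound 1 to compound 3 can be read, since each gives only a limit in this assay and not a number: the limit of > 100 ug/mL in this assay, at which 3 of the 3 values shown sit.

The compounds shown leave open whether iodo and methyl differ in effect on these cells, and how strong an inhibitor of their growth any compound is.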